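Amine substituent on the shared core: isopropyl to cyclohexyl

This account rests on a few compounds, and the source may have more. Where it says the series, first, only, none or still open, it means among the compounds named here.

Compound 2 `CC(C)Nc1ncc(-c2cccc(Cl)c2)c(-c2ccccc2)n1` gives 71% in an assay on CHO cells for displacement of a labelled ligand from adenosine receptor A1 (Homo sapiens), read by scintillation counting, with a stated time of 1 h, tested at 1 uM; on this read-out higher numbers stand for more inhibition at the one concentration tested (going by the name of the read-out) and lower numbers for less inhibition. Compound 1 `Clc1cccc(-c2cnc(NC3CCCC3)nc2-c2ccccc2)c1` in this assay gives only a limit, > 80%. Among the measured compounds shown here, compound 2 is thus the one numerical value in the set; the only other entry is the limit (the limit of > 80% in this assay, at which 1 of the 2 values shown sits), so its standing rests on a single comparison. For the measured compounds named here, the one measured step is a number at least 9 percentage points lower from compound 1 to compound 2 (that floor lies within the scatter), a cyclopentyl ring versus isopropyl on the ring nitrogen, and its floor is itself within the scatter, so the direction is suggestive rather than settled.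

Compound 3 `Clc1cccc(-c2cnc(NC3CCCCC3)nc2-c2ccccc2)c1` differs from compound 2 by cyclohexyl in place of isopropyl on a nitrogen on an aromatic ring. Cyclohexyl is a ring on the same nitrogen, as cyclopentyl is in compound 1, so the step of a number at least 9 percentage points lower from compound 1 to compound 2 (that floor lies within the scatter) is the relevant guide, read in reverse. Compound 3 is expected to give 82% in this assay, estimated between 68% and 95%, a step of a number 11 percentage points higher from compound 2 to compound 3 (beyond the scatter), with a real chance that only a limit is reported.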

Compound 3, a percentage reported as inhibition, at one concentration (the size of the read-out at that concentration, not a potency): 58%
For compound 3 the middle estimate is 24 percentage points above the measured one; measured number below the stated range.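

In this assay, the isopropylamino to cyclohexylamino change is a number 13 percentage points lower from compound 2 to compound 3 (beyond the scatter), so having a ring on this nitrogen does not in itself raise the read-out. Enlarging the ring by moving from cyclopentyl to cyclohexyl gives a number at least 22 percentage points lower from compound 1 to compound 3 (beyond the scatter), which shows that the two rings are not interchangeable at this position and that the read-out here depends on which ring is present. Compound 1 is recorded only as a limit, so this step gives a floor rather than a size: the limit of > 80% in this assay, at which 1 of the 3 values shown sits.

The compounds shown leave open how a cyclobutyl or cycloheptyl ring on this nitrogen would read, and so whether cyclopentyl marks a peak in ring size. They also leave open whether a tetrahydropyranyl ring, with an oxygen in place of a ring carbon, would behave like cyclohexyl.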